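The source may hold more compounds than are shown below. What is called first, only, known or untested is meant among the compounds shown, and "the series" means these compounds.

Compound 1 `COc1ccc(N2C(=O)COc3ccc(-c4cnc5ccccc5c4)cc32)cc1` was examined in a functional assay on HeLa cells (Homo sapiens) for antiproliferative activity, read by MTT assay, with a stated time of 72 h; a lower number here means a stronger inhibitor, a higher number a weaker inhibitor. For compound 1 the assay reports only a limit, > 40000 nM. Two other compounds were measured alongside it. Compound 2 `COc1ccc(N2C(=O)COc3ccc(-c4cnc(OC)c(NS(=O)(=O)c5ccc(F)cc5)c4)cc32)cc1` gives 1220 nM in this assay. For compound 3 `COc1cccc(N2C(=O)COc3ccc(-c4ccc(O)cc4)cc32)c1` the assay again reports only a limit, > 40000 nM. For the measured compounds named here, compound 1 thus stands at the limit of > 40000 nM in this assay, at which 2 of the 3 values shown sit, and no pair of measured compounds differs in a single place, so no measured step is available to draw on. Compound 4 `O=C1COc2ccc(-c3cnc4ccccc4c3)cc2N1C1CCCCC1` has not yet been measured. It differs from compound 1 in one place, (cyclohexyl in place of 4-methoxyphenyl on an amide-type nitrogen in a ring). Going by the values given here, with compound 1 at the limit and no comparable step measured, the change from compound 1 to compound 4 is expected to bring no gain beyond the scatter, a number no higher from compound 1 to compound 4 (the limit leaves the size open). In this assay compound 4 is therefore estimated at about 40000 nM, within a range from 10000 nM to 100000 nM, and most probably the assay will once more return only a limit for it.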

Compound 4, half-maximal inhibitory concentration: 19700 nM
For compound 4 the middle estimate is 2.0-fold (0.31 log units) above the measured one; the measured number falls inside the stated range.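

Cyclohexyl in place of 4-methoxyphenyl on the amide-type nitrogen in a ring gives an at least 2.0-fold lower number from compound 1 to compound 4 (0.30 log units; that floor lies within the scatter) in this assay. The earlier compounds shown here all carried a methoxyphenyl group on this nitrogen, whereas compound 4 shows that a non-aromatic ring of carbon only can stand there and still yield a number rather than a limit, 19700 nM. How large the step really is cannot be said, because the value of compound 1 is only a limit: the limit of > 40000 nM in this assay, at which 2 of the 4 values shown sit.

The compounds shown leave open whether cyclohexyl would have a similar effect on the core of compound 2, which has a different group on the shared core. They also do not show how a small methyl group, a longer alkyl chain or an aminoethyl chain would read on this nitrogen.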